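Cyclohexyl to benzyl on the imidazole nitrogen: second instance

The source may hold more compounds than are shown below. What is called first, only, known or untested is meant among the compounds shown, and "the series" means these compounds.

Three members of the series carry a measured value in a functional assay on SF-268 cells (Homo sapiens) for inhibition, read by sulforhodamine B assay, with a stated time of 48 h, tested at 10 uM; a lower number here means less inhibition, a higher number more inhibition at the concentration tested (going by the name of the read-out). Compound 1 `O=Cc1ccc(-c2cn3ccnc3c(-c3ccc4ncn(C5CCCCC5)c4c3)n2)cc1` gives 27.1% in this assay. Compound 2 `O=Cc1ccc(-c2cn3ccnc3c(-c3ccc4ncn(Cc5ccccc5)c4c3)n2)cc1` is the benzyl counterpart of compound 1. In this assay compound 2 gives 27.1%. The change between them, (benzyl in place of cyclohexyl on an aromatic nitrogen), produced no change at the digits printed from compound 1 to compound 2 (within the scatter). Compound 3 `c1cn2cc(-c3ccc4c(c3)ncn4C3CCCCC3)nc(-c3ccc4ncn(C5CCCCC5)c4c3)c2n1` gives 18.4% in this assay, a number within the scatter of both compound 1 and compound 2, so the three numbers give no order.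

Compound 4 `c1ccc(Cn2cnc3ccc(-c4nc(-c5ccc6c(c5)ncn6C5CCCCC5)cn5ccnc45)cc32)cc1` is not yet measured. It stands to compound 3 as compound 2 stands to compound 1: the change is benzyl in place of cyclohexyl on an aromatic nitrogen, and the place described for it is word for word the same as in the earlier pair, so this is the same change made on a different core. How the core of compound 3 differs from the core of compound 1 is not broken down here.

The expectation for compound 4 rests on a single precedent. Because no change at the digits printed from compound 1 to compound 2 (within the scatter) showed no movement, the same change on the core of compound 3 is expected to leave the read-out close to where compound 3 stands, giving an estimated step of a number 0.6 percentage points higher from compound 3 to compound 4 (within the scatter). Compound 4 is therefore estimated at 19% in this assay, with the range 8% to 31% reflecting the ordinary scatter of this kind of measurement rather than any expected effect of the change.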

Compound 4, a percentage reported as inhibition, at one concentration (the size of the read-out at that concentration, not a potency): -0.11%
Compound 4: middle estimate off by 19.1 percentage points, on the high side, outside the stated range (below it).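

In this assay, benzyl in place of cyclohexyl on an aromatic nitrogen gives a number 18.5 percentage points lower from compound 3 to compound 4 (beyond the scatter), so on the core of compound 3 this change is accompanied by a real fall in the read-out. The change therefore does not carry over from one core to the other with the same outcome, and the flat result of the first pair is no safe guide to the second: the same change on two cores in this assay, no change at the digits printed (within the scatter) from compound 1 to compound 2 and a number 18.5 percentage points lower (beyond the scatter) from compound 3 to compound 4, 18.5 percentage points apart, beyond the scatter of two such steps This shows that the result of the swap depends on the core it is made on, at least across these two pairs, but with one pair per core it does not show which difference between the cores matters, why the steps part, or whether either step would hold on a third core.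

The compounds shown leave open what other groups on the same aromatic nitrogen, such as a longer alkyl chain or a chain ending in an amine, would do on either core. They also leave open whether a carboxylic acid in place of the carbonyl-bearing aryl group of compound 1 would alter how that core responds to the swap.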